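The source may hold more compounds than are shown below. What is called first, only, known or untested is meant among the compounds shown, and "the series" means these compounds.

Two compounds of the series have numbers in an ADME assay on BV-2 cells (Mus musculus) for cytotoxicity, read by MTT assay, with a stated time of 48 h, tested at 1 uM; a higher number here means a weaker effect of the compound at the concentration tested, a lower number a stronger effect. Compound 1 `O=C1COCCN1c1ccc(/N=C\c2cn(C(=O)c3ccccc3)c3ccccc23)cc1` gives 109% in this assay, and compound 2 `O=C1COCCN1c1ccc(/N=C\c2cn(Cc3ccccc3)c3ccccc23)cc1` gives 89.3%. Within the data shown here, the one step between them, a number 19.7 percentage points lower from compound 1 to compound 2 (beyond the scatter), is the whole of what is measured. Compound 2 therefore stands lowest of the two numbers in this assay, with compound 1 nearest and higher by a step beyond the scatter.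

Compound 3 `O=C1COCCN1c1ccc(/N=C\c2cn(Cc3ccc(F)cc3)c3ccccc23)cc1` differs from compound 2 by fluoro in place of hydrogen on an aromatic carbon. Among the measured compounds shown here, no measured step bears on this change: the single step above concerns the group on the aromatic nitrogen, not the benzyl ring itself, so it offers no guide in either direction. With nothing to suggest movement, no step beyond the scatter is expected. The number expected for compound 3 in this assay is 88%, within 72% to 104%, which means an expected step of a number 1.3 percentage points lower from compound 2 to compound 3 (within the scatter).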

Compound 3, a percentage reported as activity, at one concentration (the size of the read-out at that concentration, not a potency): 87.9%
Compound 3: the middle estimate sits 0.1 percentage points above what was measured; low and high end bracket the measured number.
By their numbers in this assay, from the lowest: compounds 3 and 2 (each within the scatter of the next); then compound 1.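

Fluoro in place of hydrogen on the benzyl ring, para to a large group, is the first change shown away from the aromatic nitrogen, and in this assay it gives a number 1.4 percentage points lower from compound 2 to compound 3 (within the scatter), so this position carries the fluoro group without a readable shift. With the 4-fluorobenzyl group on the aromatic nitrogen the gap to the benzoyl compound remains, at a number 21.1 percentage points lower from compound 1 to compound 3 (beyond the scatter), so the benzyl and 4-fluorobenzyl compounds both sit apart from compound 1. No measurement shown gives a reason for either step.

As far as these compounds go, whether a methoxy group, a trifluoromethyl group or an amine at this same ring position would move the number beyond the scatter stays open. So does the effect of fluoro on the benzoyl ring of compound 1.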